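Shortening an alkyl chain on a shared core

This account rests on a few compounds, and the source may have more. Where it says the series, first, only, none or still open, it means among the compounds named here.

Compound 1 `CN1CCN(CCNC(=O)n2c(=O)n(Cc3ccccc3)c3ccccc32)CC1` gives < 6 in a functional assay for antagonist activity at 5-hydroxytryptamine receptor 4 (Cavia porcellus) (a higher number here means a more potent compound, by a factor of ten per unit of this negative logarithm, a lower number a less potent compound), which is a limit of the assay and not a number.
Compound 2 `CCCCn1c(=O)n(C(=O)NCCN2CCN(C)CC2)c2ccccc21` gives < 6 in this assay, again a limit of the assay rather than a number.

Within the data shown here, compound 2 therefore stands only at a limit: there is no measured number for it, and the limit of < 6 in this assay, at which 2 of the 2 values shown sit, shows that both values so far sit at that same limit. Among the measured compounds shown here, the single measured step, a step that the two limits leave unreadable from compound 1 to compound 2, is likewise unreadable, since both ends of it are limits, so its size cannot be told.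

Compound 3 `CCn1c(=O)n(C(=O)NCCN2CCN(C)CC2)c2ccccc21` differs from compound 2 by a single change: hydrogen in place of ethyl on a saturated chain carbon, two bonds along the chain from an aromatic nitrogen. For the measured compounds named here, no measured step bears readably on this change. With nothing pointing either way, the expectation for compound 3 is that it stays near the limit where compound 2 sits, and the step that the limit leaves unreadable from compound 2 to compound 3 is expected to be small or none beyond the scatter. The estimate for compound 3 in this assay is 5.5, with a range from 4.5 to 6.4.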

Compound 3, negative logarithm of the antagonist equilibrium constant: 6.79
Beside the measured number, compound 3's estimate is 1.29 log units below it; measured number outside the range, above it.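

Cutting the chain on the aromatic nitrogen from butyl to ethyl gives the first readable number on the shared core in this assay, and the step is a number at least 0.79 log units higher from compound 2 to compound 3 (beyond the scatter). This shows that the chain at this position matters for potency, which the earlier pair could not show, since both of its values were limits of the assay. Going by these compounds, the change from phenyl to methyl tells the same story, giving a number at least 0.79 log units higher from compound 1 to compound 3 (beyond the scatter), so ethyl is the one chain here that reaches a measured number, and the true size of both steps stays open, with only a minimum known, as the starting values are limits of the assay: the limit of < 6 in this assay, at which 2 of the 3 values shown sit.

Among these compounds, with only three compounds, a single ethyl result cannot show whether potency would go on rising as the chain gets shorter, or whether it peaks near ethyl. A methyl or a propyl group in this place would test that trend, while a chain ending in an amine or a carboxylic acid would show how far this position accepts anything other than plain carbon chains.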